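A few compounds are considered here, and "the series" means these few. Any claim that something is new, unique, unknown or untested is made for them only; others in the source may bear on it.

Among the measured compounds shown here, compound 1 `Cc1cc(C)c(CN2CCc3c(Cl)cc([C@H](CO)[C@H]4CCOC4)c(Cl)c3C2=O)c(=O)[nH]1` is the only member of the series with a single number in an assay for inhibition of histone-lysine N-methyltransferase EZH2 variant Y641N (Homo sapiens), read by scintillation counting, with a stated time of 60 min, in the presence of a further agent that is not named here; a lower number here means a stronger inhibitor, a higher number a weaker inhibitor: compound 1 gives 0.24 nM. Compound 2 `COC(c1cc(Cl)c2c(c1Cl)C(=O)N(Cc1c(C)cc(C)[nH]c1=O)CC2)C1CCOCC1` has more than one entry; in this assay compound 2 gives 310 nM; 0.1 nM (2 entries), and the several entries of compound 2 in this assay, 310 nM; 0.1 nM (2 entries) spreads widely. Compound 3 `Cc1cc(C)c(CN2CCc3c(Cl)cc([C@@H](CO)[C@@H]4CCOC4)c(Cl)c3C2=O)c(=O)[nH]1` differs from compound 1 in that (the two compounds have the same atoms and bonds and differ only in configuration as drawn: 2 of 2 stereo elements differ (all stereocentres are inverted: mirror images); a stereocentre at a saturated chain carbon is drawn R in compound 1 and S in compound 3; a stereocentre at a saturated ring carbon is drawn R in compound 1 and S in compound 3). For the measured compounds named here, no measured pair shows such a step. A loss of potency beyond the scatter is expected, because the several entries of compound 2 in this assay, 310 nM; 0.1 nM (2 entries) suggests that stereochemistry can move the number far in this assay. Compound 3 is expected at 40 nM, range 1 nM to 1500 nM, a step of a 170-fold higher number from compound 1 to compound 3 (2.22 log units; beyond the scatter) from compound 1.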

Compound 3, inhibition constant: 1260 nM
Beside the measured number, compound 3's estimate is 32-fold (1.50 log units) below it; low and high end bracket the measured number.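

In this assay, among the compounds shown here, inverting both stereocentres together gives a 5300-fold higher number from compound 1 to compound 3 (3.72 log units; beyond the scatter), the first measured step that can be read at a single change. The whole step belongs to configuration, with no atom or bond entering or leaving: the fact that compounds 1 and 3 differ only in the configuration as drawn. For the compounds shown here, the earlier spread offered no such pair, and compound 2 carries no drawn configuration: the several entries of compound 2 in this assay, 310 nM; 0.1 nM (2 entries).

On these data alone, how the step divides between the chain carbon and the ring carbon remains open. Also open, as far as these compounds go, is whether an amine in place of the hydroxyl keeps the same preference for configuration.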